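This account rests on a few compounds, and the source may have more. Where it says the series, first, only, none or still open, it means among the compounds named here.

In a functional assay on A549 cells (Homo sapiens) for inhibition, read by MTT assay, with a stated time of 48 h (on this read-out higher numbers stand for weaker inhibition and lower numbers for stronger inhibition), two related compounds have been tested so far. Compound 1 `CN(C)c1ccc(C(c2c[nH]c3ccc(Br)cc23)c2c[nH]c3ccc(Br)cc23)cc1` gives 25000 nM, a real number at which inhibition reaches the halfway point. Compound 2 `N#Cc1ccc2[nH]cc(C(c3ccc(Br)cc3)c3c[nH]c4ccc(C#N)cc34)c2c1` gives > 100000 nM, which is a limit of the assay and not a number. Compound 2 therefore stands at the weak end of what has been seen, and its entry is the limit of > 100000 nM in this assay, at which 1 of the 2 values shown sits.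

Compound 3 `CCCCCCCC(c1c[nH]c2ccc(C#N)cc12)c1c[nH]c2ccc(C#N)cc12` comes from compound 2 by one change: heptyl in place of 4-bromophenyl on a saturated chain carbon bound to two aromatic carbons, with heptyl in place of 4-bromophenyl on a saturated chain carbon bound to two aromatic carbons. Within the data shown here, no measured pair shows what a change at this place does, so any forecast here is loose. Compound 1, at 25000 nM, shows only that this family can give a number in this assay. A moderate move toward stronger inhibition is expected, and the estimated size is an at least 2.2-fold lower number from compound 2 to compound 3 (0.34 log units; beyond the scatter). Compound 3 could still stay at the limit. For compound 3 the expected value is 45000 nM, with an estimated range from 12000 nM to 100000 nM.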

Compound 3, half-maximal inhibitory concentration: 26000 nM
Compound 3: middle estimate off by 1.7-fold (0.24 log units), on the high side; low and high end bracket the measured number.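

At the saturated chain carbon bound to two aromatic carbons, an aromatic ring is not needed for a measurable effect in this assay: heptyl in place of 4-bromophenyl gives an at least 3.8-fold lower number from compound 2 to compound 3 (0.58 log units; beyond the scatter). From the compounds shown here alone, the true size of this step remains unknown, and it could be larger than printed, as compound 2 has a limit of the assay and not a number: the limit of > 100000 nM in this assay, at which 1 of the 3 values shown sits. The two groups have the same count of heavy atoms and neither carries a hydrogen-bond donor or acceptor, so this change swaps a six-membered aromatic ring and its bromine for an open carbon chain of equal heavy-atom count.

Among these compounds, the single step cannot separate the loss of the ring from the loss of the bromine, and a plain phenyl group at this place would be needed to tell these two apart. Going by these compounds, how far the effect depends on the chain also stays open, as one chain says nothing about whether a longer chain, a shorter chain such as propyl, or a chain ending in an amine or a carboxylic acid would give a lower or a higher number.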